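From fluoro to chloro on compound 2

The source may report more compounds than this note shows. Statements on the series, on what has been measured and on what is new or still open speak of the compounds shown alone.

Compound 1 `CCOC(=O)c1nn(-c2ccc(Cl)cc2)c(-c2ccc(Cl)cc2)c1CNC(C)(C)C` gives 144000 nM; > 519000 nM (2 entries) in a functional assay on NCI-H460 cells (Homo sapiens) for inhibition, read by sulforhodamine B assay, with a stated time of 48 h; on this read-out lower numbers stand for stronger inhibition of growth and higher numbers for weaker inhibition of growth. One of these entries is a number, and the other is a limit of the assay. Compound 2 `CC(C)(C)NCc1c(C(=O)O)nn(-c2ccc(Cl)cc2)c1-c1ccc(F)cc1` gives > 623000 nM in this assay. This is a limit and not a number, so compound 2 has no exact position on the scale, and a further entry for it also lacks a single number.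

Compound 3 `CC(C)(C)NCc1c(C(=O)O)nn(-c2ccc(Cl)cc2)c1-c1ccc(Cl)cc1` is reached from compound 2 by one small change, described by chloro in place of fluoro on an aromatic carbon. In words, chloro takes the place of fluoro on an aromatic carbon, turning a 4-fluorophenyl into a 4-chlorophenyl. Within the data shown here, no measured pair of compounds shows this change on its own, so the expectation has little to rest on. In this assay, no step beyond the usual scatter is expected in either direction. The expected step of an at least 1.2-fold lower number from compound 2 to compound 3 (0.09 log units; that floor lies within the scatter) is therefore only an estimate. For compound 3 the estimated value is 500000 nM, with an expected range from 150000 nM to 800000 nM.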

Compound 3, concentration for 50% growth inhibition: > 599000 nM
Compound 3 ended at the assay's limit (the forecaster's own chance of this, stated with the estimate: 75%); middle value at least 1.1-fold (0.07 log units) away from the limit.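

In this assay, among these compounds, compound 2 and compound 3 each end at a limit and not at a number, and no step between them can be read. The compounds shown leave open how strongly compound 2 and compound 3 inhibit growth, and whether a 4-chlorophenyl and a 4-fluorophenyl differ at all here.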